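One ring larger, sulfur swapped for oxygen

A few compounds are considered here, and "the series" means these few. Any claim that something is new, unique, unknown or untested is made for them only; others in the source may bear on it.

Measured so far:
compound 1 `CCCC/N=C(\S)OC[C@H]1OC(n2cnc3c(NC4CCOC4)ncnc32)[C@H](O)[C@@H]1O`, an assay on DDT1 cells (Cricetulus griseus) for binding affinity to adenosine receptor A1 (Homo sapiens), read by radioligand binding; on this read-out higher numbers stand for weaker inhibition and lower numbers for stronger inhibition: 157 nM
compound 2 `O[C@@H]1[C@@H](CO/C(S)=N/C2CC2)OC(n2cnc3c(NC4CCOC4)ncnc32)[C@@H]1O`, this assay: 157 nM

Compound 2 stands level with compound 1 at the digits shown. Among the measured compounds shown here, the only measured step, no change at the digits printed from compound 1 to compound 2 (within the scatter), came from putting a cyclopropyl in place of a butyl on the double-bonded nitrogen. Compound 3 `O=C(NC1CCC1)OC[C@H]1OC(n2cnc3c(NC4CCOC4)ncnc32)[C@H](O)[C@@H]1O` differs from compound 2 by a group of 7 heavy atoms (5 carbon, 1 nitrogen, 1 oxygen; one four-membered non-aromatic ring of carbon only) in place of a group of 6 heavy atoms (4 carbon, 1 nitrogen, 1 sulfur; one three-membered non-aromatic ring of carbon only), on an oxygen on a saturated carbon. For the measured compounds named here, the measured step bears on this only in part: it shows that the group on that nitrogen can change without effect, while the sulfur-for-oxygen swap has no measured counterpart. In this assay a small step at most is expected, a 1.4-fold higher number from compound 2 to compound 3 (0.15 log units; within the scatter). Compound 3 is therefore estimated at 220 nM, within 60 nM to 800 nM.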

Compound 3, inhibition constant: 306 nM
Compound 3: the middle estimate sits 1.4-fold (0.14 log units) below what was measured; measured number inside the range.
By their numbers in this assay, from the lowest: compounds 1, 2 and 3 (each within the scatter of the next).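

In this assay, putting cyclobutylcarbamoyl on the oxygen on a saturated carbon, with oxygen taking the place of sulfur, gives a 1.9-fold higher number from compound 2 to compound 3 (0.29 log units; within the scatter); measured against the butyl group, it gives a 1.9-fold higher number from compound 1 to compound 3 (0.29 log units; within the scatter). So this position accepts the sulfur-to-oxygen swap and a four-membered ring together without leaving the scatter. Both steps change the sulfur and the ring or chain at once, so neither change can be read alone, and no supporting measurement bears on this result.

Still open, on these data alone, is how a phenyl ring or a longer chain such as hexyl on that nitrogen would read. The same goes for butylcarbamoyl or cyclopropylcarbamoyl, which would isolate the sulfur-to-oxygen swap.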